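The compounds below may be only part of what the source reports. "The series", "measured", "known", "first", "only" and "open" are said of these compounds alone.

The measured compounds:
compound 1, `CC1CCN(c2ccc3cc(NC(=O)CCc4ccc(C(F)(F)F)cc4)ccc3n2)C1`, 2 nM
compound 2, `CC(C)C(=O)NC1CCN(c2ccc3cc(NC(=O)CCc4ccc(C(F)(F)F)cc4)ccc3n2)C1`, 1 nM
compound 3, `O=C(CCc1ccc(C(F)(F)F)cc1)Nc1ccc2nc(N3CC4CC3CO4)ccc2c1`, 13 nM

All three were tested in an assay on isolated protein for displacement of a labelled ligand from melanin-concentrating hormone receptor 1 (Homo sapiens); a higher number here means a weaker inhibitor, a lower number a stronger inhibitor. Compound 3 gives the highest number of the three: the nearest is compound 1, with a 6.5-fold higher number from compound 1 to compound 3 (0.81 log units; beyond the scatter), and the furthest is compound 2, with a 13-fold higher number from compound 2 to compound 3 (1.11 log units; beyond the scatter). Both steps are beyond the scatter, and both exchange a five-membered ring with one hetero atom for the two-ring group of compound 3. Between compound 1 and compound 2 the step of a 2.0-fold lower number from compound 1 to compound 2 (0.30 log units; within the scatter) lies within the scatter.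

Compound 4, `O=C(CCc1ccc(C(F)(F)F)cc1)Nc1ccc2nc(N3CCCCCC3)ccc2c1`, is not yet measured. It differs from compound 3 in one place: a group of 7 heavy atoms (6 carbon, 1 nitrogen; one seven-membered non-aromatic ring with 1 hetero atom) in place of a group of 7 heavy atoms (5 carbon, 1 nitrogen, 1 oxygen; 2 five-membered non-aromatic rings with 1 hetero atom each), on an aromatic carbon. Among the measured compounds shown here, the incoming azepan-1-yl group, like the ring of compound 1, is a single non-aromatic ring with one hetero atom, so the steps that bear on this change are a 6.5-fold higher number from compound 1 to compound 3 (0.81 log units; beyond the scatter) and a 13-fold higher number from compound 2 to compound 3 (1.11 log units; beyond the scatter), read in reverse. For the measured compounds named here, compound 3 is the only compound carrying the two-ring group, and nothing shows how a seven-membered ring compares with a five-membered one. Compound 4 is therefore expected to give a lower number than compound 3 in this assay, a step of about a 3.3-fold lower number from compound 3 to compound 4 (0.51 log units; beyond the scatter), toward the value of compound 1. The estimate for compound 4 is 4 nM, with a range from 1.5 nM to 12 nM.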

Compound 4, half-maximal inhibitory concentration: 36 nM
The estimate for compound 4 lay 9.0-fold (0.95 log units) below the measured number, outside the stated range (above it).
By their numbers in this assay, from the lowest: compounds 2 and 1 (each within the scatter of the next); then compound 3; then compound 4.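

In this assay, the azepan-1-yl group does not bring the number back toward those of the pyrrolidine compounds, as the large steps show: an 18-fold higher number from compound 1 to compound 4 (1.26 log units; beyond the scatter) and a 36-fold higher number from compound 2 to compound 4 (1.56 log units; beyond the scatter). A single non-aromatic ring with one hetero atom on this aromatic carbon, next to the ring nitrogen, is therefore not enough to give a low number, and the two-ring group of compound 3 is no longer the least favourable group seen at this position, with a 2.8-fold higher number from compound 3 to compound 4 (0.44 log units; beyond the scatter), a modest step but beyond the scatter. Nothing given here accounts for the difference between these rings.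

Both single-ring comparisons change ring size and substitution together, so the compounds shown cannot separate the enlargement to seven members from the loss of the methyl or (isopropylcarbonyl)amino substituent, a question that unsubstituted pyrrolidin-1-yl would address. They also leave open how piperidin-1-yl, the six-membered ring between these sizes, or morpholin-4-yl, a single ring that carries an oxygen as the two-ring group does, would compare at this position.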